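The compounds below may be only part of what the source reports. "The series", "measured", "known", "first", "only" and "open" are said of these compounds alone.

Measured so far in a functional assay on K562 cells (Homo sapiens) for inhibition, read by MTT assay, with a stated time of 72 h, tested at 10 uM; on this read-out higher numbers stand for more inhibition at the one concentration tested (going by the name of the read-out) and lower numbers for less inhibition:
Compound 1 `CCOC(=O)C1=C(Nc2ccccc2)S/C(=C\c2ccc(OC)cc2)C1=O` gives 9.6%.
Compound 2 `CCOC(=O)C1=C(Nc2ccccc2)S/C(=C\c2ccccc2C(F)(F)F)C1=O` gives 19.7%.
Compound 3 `CCOC(=O)C1=C(Nc2ccccc2)S/C(=C\c2ccc(C(=O)OCC)[nH]2)C1=O` gives 18.6%.

All three numbers are small, so the series as a whole shows little inhibition at the concentration tested. Compound 1 has the lowest number of the three. Its gap to compound 3 lies within the usual scatter, so the two cannot be told apart. Its gap to compound 2 lies beyond the scatter, so compound 2 gives a larger number in this assay than compound 1 does. No pair of these compounds differs in only one place, so no single structural step can be read off the measured set.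

Compound 4 `CCOC(=O)C1=C(Nc2ccccc2)S/C(=C\c2cccnc2)C1=O` is not yet measured. Relative to compound 1 the change is pyridin-3-yl in place of 4-methoxyphenyl on a double-bonded chain carbon bound to a double-bonded ring carbon. The rest of the shared core is kept. Among the measured compounds shown here, nothing among the measured compounds shows how a pyridin-3-yl group in this place behaves, and the three numbers together give no sign that exchanging the group on the double-bonded chain carbon moves the read-out far. The step in this assay is therefore expected to be small, probably within the scatter, with no firm direction. Compound 4 is estimated at 13%, with a range from 3% to 28%. The expected step is a number 3.4 percentage points higher from compound 1 to compound 4 (within the scatter).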

Compound 4, a percentage reported as inhibition, at one concentration (the size of the read-out at that concentration, not a potency): < 10%
Compound 4 gave a limit, no number; the forecaster's own chance of this, stated with the estimate: 2%; middle value at least 3 percentage points away from the limit.
By their numbers in this assay, from the lowest: compounds 1, 3 and 2 (each within the scatter of the next, the first and the last beyond it).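

In this assay compound 4 gives < 10%, a limit and not a number, so no step from compound 1 to compound 4 can be read: the limit of < 10% in this assay, at which 1 of the 4 values shown sits.

On these data alone, whether pyridin-3-yl in place of 4-methoxyphenyl on the double-bonded chain carbon moves the read-out at all, and in which direction, stays open.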